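Swapping chloro for acetyl on the shared core

The source may hold more compounds than are shown below. What is called first, only, known or untested is meant among the compounds shown, and "the series" means these compounds.

Of the compounds shown here, three sharing one core have been tested in an assay on isolated protein (strain Sprague-Dawley) for inhibition of Amine oxidase [flavin-containing] B (Rattus norvegicus), read by spectrophotometry, with a stated time of 5 min; on this read-out lower numbers stand for stronger inhibition and higher numbers for weaker inhibition. Compound 1 `O=c1cc(O)c2ccc(OCc3cccc(Br)c3)cc2o1` gives 490 nM. Compound 2 `O=c1cc(Cl)c2ccc(OCc3cccc(Cl)c3)cc2o1` gives 20.9 nM. Compound 3 `O=c1cc(CO)c2ccc(OCc3cccc(Br)c3)cc2o1` gives 14.1 nM. On these numbers compound 2 stands second highest of the three: its nearest neighbour is compound 3, a step within the scatter, while compound 1 lies well beyond the scatter above it.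

Compound 4 `CC(=O)c1cc(=O)oc2cc(OCc3cccc(Cl)c3)ccc12` is still to be measured in this assay. It differs from compound 2 in one place: acetyl in place of chloro on an aromatic carbon. Among the measured compounds shown here, the only measured step at this place is a 35-fold lower number from compound 1 to compound 3 (1.54 log units; beyond the scatter), a large drop, but it exchanges hydroxy for hydroxymethyl, neither of which is involved here, so it bears on the present change only loosely. The pair of compound 2 and compound 3 shows that chloro and hydroxymethyl at this place give numbers within the scatter of each other, which suggests the position tolerates varied groups.

For compound 4, then, a step of a 1.1-fold higher number from compound 2 to compound 4 (0.02 log units; within the scatter) is expected, that is, none beyond the scatter. The estimate for compound 4 in this assay is 22 nM, within a range from 7 nM to 70 nM.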

Compound 4, half-maximal inhibitory concentration: 39.8 nM
Estimate against measurement, compound 4: 1.8-fold (0.26 log units) below; measured number inside the range.
By their numbers in this assay, from the lowest: compounds 3, 2 and 4 (each within the scatter of the next, the first and the last beyond it); then compound 1.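

The step of a 1.9-fold higher number from compound 2 to compound 4 (0.28 log units; within the scatter) in this assay gives the first direct view of an exchange starting from chloro at this place. Acetyl brings more heavy atoms and a hydrogen-bond acceptor that chloro lacks, yet the step stays within the scatter, whereas the only earlier step here, a 35-fold lower number from compound 1 to compound 3 (1.54 log units; beyond the scatter), is large, so this place does not respond alike to every exchange. Nothing available explains either outcome.

The compounds shown leave open whether an amine, a carboxylic acid or a longer chain such as a butyryl group at this place would also stay within the scatter of chloro. On these data alone, it also remains open whether acetyl would behave the same way on the bromo-bearing version of the shared core.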